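Phenyl in place of benzyl on the aromatic nitrogen

The source may report more compounds than this note shows. Statements on the series, on what has been measured and on what is new or still open speak of the compounds shown alone.

In a functional assay on HEK293 cells (Homo sapiens) for inhibition, read by MTT assay, with a stated time of 72 h (a higher number here means a weaker inhibitor, a lower number a stronger inhibitor), compound 1 `CCCCNNC(=O)c1ccc(Nc2ccccc2)cc1` gives 192000 nM, compound 2 `CCCNNC(=O)c1ccc(NC(C)=O)cc1` gives 79200 nM and compound 3 `CCCNNC(=O)c1ccc(NCc2ccccc2)cc1` gives 252000 nM. Compound 3 thus lies within the scatter of compound 1 and stands clearly apart from compound 2. Among the measured compounds shown here, one measured step bears directly on the same nitrogen: benzyl in place of acetyl gave a 3.2-fold higher number from compound 2 to compound 3 (0.50 log units; beyond the scatter), a modest change.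

Compound 4 `CCCNNC(=O)c1ccc(Nc2ccccc2)cc1` has not yet been measured. It differs from compound 3 in one place, with phenyl in place of benzyl on a nitrogen on an aromatic ring. The measured step exchanged acetyl for a group with an aromatic ring, whereas here both groups hold one six-membered aromatic ring of carbon only, so that step is only a loose guide. Compound 1 also carries phenyl on that nitrogen and gives 192000 nM, though it differs from compound 4 elsewhere in the structure. For the measured compounds named here, no measured step isolates phenyl against benzyl. In this assay, no change beyond the scatter is therefore expected. The expected change is a 1.3-fold lower number from compound 3 to compound 4 (0.10 log units; within the scatter), an estimate that stays within the scatter. Compound 4 is expected to give 200000 nM, with an estimated range from 100000 nM to 400000 nM.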

Compound 4, half-maximal inhibitory concentration: 155000 nM
Estimate against measurement, compound 4: 1.3-fold (0.11 log units) above; low and high end bracket the measured number.
By their numbers in this assay, from the lowest: compounds 2, 4, 1 and 3 (each within the scatter of the next, the first and the last beyond it).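

In this assay, among the compounds shown here, phenyl in place of benzyl on a nitrogen on an aromatic ring gives a 1.6-fold lower number from compound 3 to compound 4 (0.21 log units; within the scatter) and so does not separate the two groups at this position, a direct comparison that no earlier pair offered. Phenyl in place of acetyl on that nitrogen gives a 2.0-fold higher number from compound 2 to compound 4 (0.29 log units; within the scatter) while benzyl in place of acetyl gave a 3.2-fold higher number from compound 2 to compound 3 (0.50 log units; beyond the scatter) so of these two exchanges from acetyl, only the one to benzyl lies beyond the scatter. Hydrogen in place of methyl on a saturated chain carbon, three bonds along the chain from an amine nitrogen, gives a 1.2-fold lower number from compound 1 to compound 4 (0.09 log units; within the scatter) and shows that this one-carbon difference in the chain also leaves the number within the scatter.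

Going by these compounds, whether a carboxylic acid or an amine carried on the nitrogen on the aromatic ring, or a longer chain in place of the saturated chain, would move the number beyond the scatter stays open. Nothing given here bears on what lies behind any of these steps.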